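A few compounds are considered here, and "the series" means these few. Any claim that something is new, unique, unknown or untested is made for them only; others in the source may bear on it.

Compound 3 `CCOc1ccc(Nc2nc(SCc3ccc(C(F)(F)F)cc3)nc3ccccc23)cc1` was tested in a functional assay on HGC-27 cells (Homo sapiens) for cytotoxicity, read by MTT assay, with a stated time of 72 h (on this read-out lower numbers stand for stronger inhibition and higher numbers for weaker inhibition), and in it compound 3 gives 33000 nM. Among the two numbers available this is the highest, the nearest neighbour being compound 2 `FC(F)(F)c1ccc(CSc2nc(Nc3cccc(Cl)c3)c3ccccc3n2)cc1`, for which this assay gives 19900 nM; the step from one to the other reads a 1.7-fold higher number from compound 2 to compound 3 (0.22 log units; within the scatter). Compound 1 `FC(F)(F)c1ccc(CSc2nc(Nc3ccccc3C(F)(F)F)c3ccccc3n2)cc1` is not a number but a limit of this assay, recorded as > 50000 nM; that is the limit described as the limit of > 50000 nM in this assay, at which 1 of the 3 values shown sits. Measured from that limit, the step to compound 2 is an at least 2.5-fold lower number from compound 1 to compound 2 (0.40 log units; beyond the scatter), and the step to compound 3 is an at least 1.5-fold lower number from compound 1 to compound 3 (0.18 log units; that floor lies within the scatter).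

Compound 4 `Fc1ccc(Nc2nc(SCc3ccc(C(F)(F)F)cc3)nc3ccccc23)cc1Cl` has not yet been measured. It differs from compound 3 by 3-chloro-4-fluorophenyl in place of 4-ethoxyphenyl on a nitrogen on an aromatic ring. For the measured compounds named here, the step that bears on this change most directly is the one between compound 2 and compound 3, which carried a 3-chlorophenyl against a 4-ethoxyphenyl and stayed within the scatter; the entering 3-chloro-4-fluorophenyl shares the chlorine on the ring with compound 2. On this basis the step from compound 3 to compound 4 in this assay is expected to be small, about a 1.7-fold lower number from compound 3 to compound 4 (0.22 log units; within the scatter). Compound 4 is therefore estimated at 20000 nM, with a range from 7000 nM to 50000 nM.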

Compound 4, half-maximal inhibitory concentration: 14700 nM
Compound 4: middle estimate off by 1.4-fold (0.13 log units), on the high side; measured number inside the range.
By their numbers in this assay, from the lowest: compounds 4, 2 and 3 (each within the scatter of the next, the first and the last beyond it). At a limit, above all of these: compound 1.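

In this assay, 3-chloro-4-fluorophenyl in place of 4-ethoxyphenyl on the nitrogen gives a 2.2-fold lower number from compound 3 to compound 4 (0.35 log units; beyond the scatter), the first step involving compound 3 that is printed as beyond the scatter, since its earlier steps from compound 1 and compound 2 stayed inside it or had a floor inside it. Fluoro in place of hydrogen on an aromatic carbon does not separate the two halogen-bearing compounds, with a 1.4-fold lower number from compound 2 to compound 4 (0.13 log units; within the scatter), so the position tolerates that addition without a readable difference, and only compound 4, not compound 2, stands clear of compound 3. Compound 1 remains a limit and not a number, so its step, an at least 3.4-fold lower number from compound 1 to compound 4 (0.53 log units; beyond the scatter), gives only a floor: the limit of > 50000 nM in this assay, at which 1 of the 4 values shown sits.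

The compounds shown leave open whether a plain 4-fluorophenyl on that nitrogen would read like the 3-chloro-4-fluorophenyl, which would tell the part played by the fluorine from that of the chlorine. They also leave open what an amine or a carboxylic acid on this aromatic ring would do to the number, as every group shown here carries only halogen, trifluoromethyl or ethoxy.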